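The compounds below may be only part of what the source reports. "The series", "measured", "known", "first", "only" and "open" are said of these compounds alone.

Working notes on the series. Three compounds have numbers in an assay on microsomes from liver (strain Wistar) for inhibition of acyl-CoA desaturase 1 (Rattus norvegicus), with stated times of 10 min and 1 h; on this read-out higher numbers stand for weaker inhibition and lower numbers for stronger inhibition. Compound 1 `O=C(NCc1cccs1)c1ccc2[nH]c(-c3ccc(Oc4ccccc4)cc3)nc2c1` gives 3760 nM. Compound 2 `OC(c1ccc2[nH]c(-c3ccc(OCc4ccccc4)cc3)nc2c1)c1ccccc1C(F)(F)F` gives 82 nM. Compound 3 `O=C(NCc1nccs1)c1ccc2[nH]c(-c3ccc(Oc4ccccc4Cl)cc3)nc2c1` gives 115 nM. Of these three numbers compound 3 holds the second highest; its gap to compound 2 lies within the scatter of repeated runs, so the two cannot be told apart, whereas compound 1 stands well apart with a higher number, beyond the scatter, meaning weaker inhibition in this assay.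

Compound 4 `O=C(NCc1ccc(Cl)s1)c1ccc2[nH]c(-c3ccc(Oc4ccccc4Cl)cc3)nc2c1` is not yet measured. It differs from compound 3 in one place: 5-chlorothiophen-2-yl in place of 1,3-thiazol-2-yl on a saturated chain carbon bound to an amide-type nitrogen. Going by the values given here, no pair of measured compounds differs in this way, so nothing in the numbers at hand sets the size of such a step. Both groups are five-membered aromatic rings carrying a methylene to the amide nitrogen, and the expected step is a 1.3-fold lower number from compound 3 to compound 4 (0.11 log units; within the scatter), that is, none beyond the scatter in either direction. On that basis compound 4 is estimated at 90 nM, with a range from 30 nM to 300 nM.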

Compound 4, half-maximal inhibitory concentration: 832 nM
Beside the measured number, compound 4's estimate is 9.2-fold (0.97 log units) below it; measured number outside the range, above it.
By their numbers in this assay, from the lowest: compounds 2 and 3 (each within the scatter of the next); then compound 4; then compound 1.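

The saturated chain carbon bound to an amide-type nitrogen is sensitive to the ring it carries: in this assay, 5-chlorothiophen-2-yl in place of 1,3-thiazol-2-yl gives a 7.2-fold higher number from compound 3 to compound 4 (0.86 log units; beyond the scatter). Going by these compounds alone, this is the first step that can be read at one place, and it shows that these two five-membered aromatic rings are not interchangeable there. No measurement at hand bears on the reason for this step.

The step changes the ring hetero atoms and adds chlorine together, so their separate contributions remain unresolved; thiophen-2-yl or 5-chloro-1,3-thiazol-2-yl on the same chain carbon, with the rest of compound 3 kept, would divide them. Also open, going by these compounds, is how an open-chain group such as 2-methoxyethyl on the amide nitrogen would compare with either ring-bearing group.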